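Swapping a Benzyl Arm for a Halogenated Phenyl Ring

The source may report more compounds than this note shows. Statements on the series, on what has been measured and on what is new or still open speak of the compounds shown alone.

Of the compounds shown here, three sharing one core have been tested in an ADME assay for permeability, using PAMPA, with a stated time of 30 min, at pH 7.4; on this read-out higher numbers stand for higher permeability and lower numbers for lower permeability. Compound 1 `COc1cccc(CNCCCNc2ccnc3cc(-c4ccc(F)cc4)ccc23)c1O` gives 237 10^-6 cm/s, and compound 3 `COc1ccc(Oc2ccc3c(NCCCNCc4cc(F)ccc4OC)ccnc3c2)cc1` gives 317 10^-6 cm/s. Compound 2 `c1ccc(CCc2ccc3c(NCCCNCc4ccco4)ccnc3c2)cc1` gives 23 10^-6 cm/s, which is the lowest of the three numbers: the gap to compound 1 and the gap to compound 3 both lie beyond the usual scatter of repeated measurements, so compound 2 clearly stands apart from the other two.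

Compound 4 `Fc1ccc(Cc2ccc3c(NCCCNCc4ccco4)ccnc3c2)c(Cl)c1` has not yet been measured in this assay. It is built from compound 2 by a single change: 2-chloro-4-fluorophenyl in place of benzyl on a saturated chain carbon bound to an aromatic carbon. Going by the values given here, no step between two measured compounds shows what this kind of exchange does to permeability, so the expectation rests on compound 2 alone and on the nature of the change.

A modest upward step is expected, of a size that may or may not exceed the scatter, giving a 2.0-fold higher number from compound 2 to compound 4 (0.29 log units; within the scatter). The estimated permeability of compound 4 in this assay is therefore 45 10^-6 cm/s, with a plausible range from 15 10^-6 cm/s to 130 10^-6 cm/s, and the result for compound 4 will show whether the expectation holds.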

Compound 4, apparent permeability: 23 10^-6 cm/s
Compound 4: the middle estimate sits 2.0-fold (0.29 log units) above what was measured; the range from low to high includes it.
By their numbers in this assay, from the lowest: compounds 2 and 4 (each within the scatter of the next); then compounds 1 and 3 (each within the scatter of the next).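

In this assay, going by these compounds alone, the first step at this position shows no change at the digits printed from compound 2 to compound 4 (within the scatter) when 2-chloro-4-fluorophenyl takes the place of benzyl on a saturated chain carbon bound to an aromatic carbon. Read one bond further out, this is phenethyl giving way to 2-chloro-4-fluorobenzyl, and the two groups match in what is counted for them: one six-membered aromatic ring of carbon only, no hydrogen-bond donors or acceptors, and no net charge, while chlorine and fluorine enter. So at this position, in the setting of compound 2, adding these two halogens comes with no shift in the read-out that stands out from ordinary repeat variation, although nothing available here explains this outcome.

A single step cannot tell whether a group of another kind on the same carbon, such as a primary amine or a carboxylic acid, would leave the number just as unmoved. As far as these compounds go, it also remains open whether the same exchange would read the same way on a compound built like compound 1 or compound 3.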